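The compounds below may be only part of what the source reports. "The series", "measured", "known", "first", "only" and "open" are said of these compounds alone.

In a functional assay on HepG2 cells (Homo sapiens) for inhibition, read by MTT assay, with a stated time of 72 h (a higher number here means a weaker inhibitor, a lower number a stronger inhibitor), compound 1 `COc1ccc(-c2nnc(SCCCN3CCN(c4nc5ccccc5o4)CC3)o2)cc1` gives 66100 nM, compound 2 `CC(C)(C)Oc1ccc(-c2nnc(SCCCN3CCN(c4nc5ccccc5o4)CC3)o2)cc1` gives 121000 nM and compound 3 `COc1ccc(-c2nnc(SCCCN3CCN(c4nc5ccccc5s4)CC3)o2)cc1` gives 134000 nM. All three are weak inhibitors. Compound 3 lies within the scatter of compound 2, and it reads weaker than compound 1 by a modest margin. The next compound, compound 4 `c1ccc(-c2nnc(SCCCN3CCN(c4nc5ccccc5s4)CC3)o2)cc1`, carries hydrogen in place of methoxy on an aromatic carbon, so 4-methoxyphenyl becomes phenyl. Among the measured compounds shown here, no measured step removes this group outright, so the evidence is indirect. The closest comparison is tert-butyl in place of methyl on the same oxygen, which gave a 1.8-fold higher number from compound 1 to compound 2 (0.26 log units; within the scatter). The other measured step, 1,3-benzothiazol-2-yl in place of 1,3-benzoxazol-2-yl, gave a 2.0-fold higher number from compound 1 to compound 3 (0.31 log units; beyond the scatter) at a different place in the molecule. Neither step is large, so no change beyond the scatter is expected in this assay, and no direction can be favoured. The expected step is a 1.2-fold lower number from compound 3 to compound 4 (0.07 log units; within the scatter). The estimate for compound 4 is 115000 nM, with an expected range from 50000 nM to 250000 nM.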

Compound 4, half-maximal inhibitory concentration: 217000 nM
Compound 4: middle estimate off by 1.9-fold (0.28 log units), on the low side; low and high end bracket the measured number.
By their numbers in this assay, from the lowest: compounds 1, 2, 3 and 4 (each within the scatter of the next, the first and the last beyond it).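

Compound 3 and compound 4 give the first direct test of removing the methoxy group outright, where the earlier step only enlarged the group on the oxygen. In this assay, going from 4-methoxyphenyl to phenyl gives a 1.6-fold higher number from compound 3 to compound 4 (0.21 log units; within the scatter), so this pair gives no sign that the methoxy group matters for the read-out, at least with 1,3-benzothiazol-2-yl on the ring amine nitrogen. Nothing available explains why this position tolerates the loss of the group.

The compounds shown leave open whether the same removal would also stay within the scatter with 1,3-benzoxazol-2-yl in place of 1,3-benzothiazol-2-yl. They also leave open whether an amine or a carboxylic acid on this aromatic carbon would shift the number beyond the scatter.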